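From Trifluoromethyl to Cyano: An Expected Step

This account rests on a few compounds, and the source may have more. Where it says the series, first, only, none or still open, it means among the compounds named here.

Compound 1, `O=C(Nc1cc(C(F)(F)F)cc(C(F)(F)F)c1)c1cc(Br)ccc1O`, in an assay for inhibition of transmembrane protease serine 4 (Homo sapiens), read by fluorescence; on this read-out higher numbers stand for weaker inhibition and lower numbers for stronger inhibition: 13000 nM
Compound 2, `O=C(Nc1ccc(C(F)(F)F)c(C(F)(F)F)c1)c1cc(Cl)ccc1O`: 13000 nM
Compound 3, `O=C(Nc1ccc(C(F)(F)F)cc1)c1cc(Cl)ccc1O`: 16000 nM

The three measured compounds share one core and differ only in the groups on the aromatic ring attached to the amide nitrogen. Compound 3 carries the highest of the three numbers, yet its gap to compound 1 and to compound 2 lies within the scatter, so no order among the three can be read from these values. Within the data shown here, the one single-point step on record, a 1.2-fold higher number from compound 2 to compound 3 (0.09 log units; within the scatter), removed a trifluoromethyl group and left the number essentially where it was.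

Compound 4, `N#Cc1ccc(NC(=O)c2cc(Cl)ccc2O)cc1`, differs from compound 3 by cyano in place of trifluoromethyl on an aromatic carbon. Among the measured compounds shown here, the only step that bears on this change is the one from compound 2 to compound 3, which stayed within the scatter, so a change of the group at this position is expected to move this assay by no more than the scatter, in no particular direction. The step from compound 3 to compound 4 is therefore estimated as no change at the digits printed from compound 3 to compound 4 (within the scatter). Compound 4 is expected to give about 16000 nM, with a likely range from 6000 nM to 40000 nM.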

Compound 4, half-maximal inhibitory concentration: 76000 nM
For compound 4 the middle estimate is 4.8-fold (0.68 log units) below the measured one, and the stated range ends below it.
By their numbers in this assay, from the lowest: compounds 1, 2 and 3 (each within the scatter of the next); then compound 4.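

In this assay, among these compounds, cyano in place of trifluoromethyl, para to a large group, produced the first change in this set that stands clear of the scatter: a 4.8-fold higher number from compound 3 to compound 4 (0.68 log units; beyond the scatter), which means weaker inhibition. The earlier step, a 1.2-fold higher number from compound 2 to compound 3 (0.09 log units; within the scatter), removed one of two trifluoromethyl groups and could not be told apart from no change, so it gave no sign that a swap at this position could matter. Nothing measured here accounts for the weaker inhibition after this swap.

A methyl group or an amine at this position would help show whether the result follows from cyano entering or from trifluoromethyl leaving. Going by these compounds, it also remains open whether the same swap would have a similar effect with a second trifluoromethyl group on the ring.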